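Side chain change on the core of compound 3

The compounds below may be only part of what the source reports. "The series", "measured", "known", "first", "only" and "open" are said of these compounds alone.

Compound 1 `CC1=NN(S(=O)(=O)c2ccc(C)cc2)C(c2cc(Br)cc(Br)c2O)C1` gives "not active" (no number reported) in a functional assay on MGC-803 cells (Homo sapiens) for cytotoxicity, read by MTT assay, with a stated time of 48 h; a higher number here means a weaker inhibitor, a lower number a stronger inhibitor. Compound 2 `CC1=NN(C(=O)CN2CCN(C(=O)OC(C)(C)C)CC2)C(c2ccccc2O)C1` gives 17600 nM in this assay. Compound 3 `CCC(=O)N1N=C(c2cc3ccccc3oc2=O)CC1c1ccccc1` gives 5300 nM in this assay, the lowest of the two numbers; the value of compound 2 stands beyond the scatter from it, so compound 3 is the stronger of the two. Compound 4 `CC1CCCN(CC(=O)N2N=C(c3cc4ccccc4oc3=O)CC2c2ccccc2)C1` carries the change (3-methylpiperidin-1-yl in place of methyl on a saturated chain carbon bound to a carbonyl carbon). For the measured compounds named here, no step between two measured compounds shows what such a change does on this core; compound 2, with a related acyl side chain on a different core, gives only 17600 nM, but its core differs as well, so that reading is uncertain. A modest weakening is expected for the step of a 1.5-fold higher number from compound 3 to compound 4 (0.18 log units; within the scatter), near the edge of the scatter. Compound 4 is estimated at 8000 nM, with a range from 2500 nM to 25000 nM.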

Compound 4, half-maximal inhibitory concentration: "not active" (no number reported)
Compound 4 has no reported number here; there is nothing to compare the estimate with.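

For the compounds shown here, with no number for compound 4, no step from compound 3 can be read, and no evidence bears on this result. The compounds shown leave open how far 3-methylpiperidin-1-yl in place of methyl shifts activity on this core.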